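The compounds below may be only part of what the source reports. "The series", "measured", "known", "first", "only" and "open" are said of these compounds alone.

Measured in an in vivo ADME assay on the whole organism for pharmacokinetics, with Rattus norvegicus as the target, at a dose of 20 mg/kg by the oral route; a higher number here means more compound in the circulation at the dose given, a lower number less compound in the circulation:
- compound 1 `O=C(NO)c1c(S(=O)(=O)N2CCC(Oc3ccc(C(F)(F)F)cc3)CC2)ccc2c1OCCO2`: 6370 nM
- compound 2 `O=C(NO)c1c(Cl)cccc1S(=O)(=O)N1CCC(Oc2ccc(C(F)(F)F)cc2)CC1`: 2740 nM

Compound 2 holds the lower of these two numbers, and its gap to compound 1 lies beyond the usual scatter. The next compound, compound 3 `COCCOc1cccc(S(=O)(=O)N2CCC(Oc3ccc(C(F)(F)F)cc3)CC2)c1C(=O)NO`, is compound 2 with 2-methoxyethoxy in place of chloro on an aromatic carbon, ortho to a hydroxycarbamoyl group: 2-methoxyethoxy in place of chloro on an aromatic carbon. Within the data shown here, no measured pair differs in a single place, so no direct precedent exists for this exchange in this assay. With compound 1 at 6370 nM as the only other reference, a small rise is expected, or none beyond the scatter. The expected change is a 1.2-fold higher number from compound 2 to compound 3 (0.08 log units; within the scatter). Compound 3 is estimated at 3300 nM, with an expected range of 1100 nM to 9000 nM.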

Compound 3, maximal plasma concentration: 5150 nM
Compound 3: the middle estimate sits 1.6-fold (0.19 log units) below what was measured; measured number inside the range.
By their numbers in this assay, from the lowest: compounds 2, 3 and 1 (each within the scatter of the next, the first and the last beyond it).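

Placing 2-methoxyethoxy in place of chloro on the aromatic carbon ortho to a hydroxycarbamoyl group gives, in this assay, a 1.9-fold higher number from compound 2 to compound 3 (0.27 log units; within the scatter). This single-place step shows that the position can carry a chain of 5 heavy atoms with 2 hydrogen-bond acceptors in place of a lone chlorine, with the read-out staying within the usual scatter. No supporting measurement bears on this result.

The compounds shown leave open whether an amine, a carboxylic acid or a longer ether chain at this position would also stay within the scatter of compound 2 in this assay. They also leave open whether the same exchange would give a similar step on any other carbon of this ring.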